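Losing the epoxide ether: what bromo may do

The compounds below may be only part of what the source reports. "The series", "measured", "known", "first", "only" and "open" are said of these compounds alone.

Measured in a functional assay on U-251 cells (Homo sapiens) for cytotoxicity; a lower number here means a stronger inhibitor of growth, a higher number a weaker inhibitor of growth:
- compound 1 `COc1ccc(C2=C(c3ccc(SC)cc3)CC3CCCN3C2=O)cc1Br`: 800 nM
- compound 2 `CSc1ccc(C2=C(c3ccc(F)c(F)c3)C(=O)N3CCCC3C2)cc1`: 15000 nM
- compound 3 `CSc1ccc(C2=C(c3ccc(OCC4CO4)cc3)C(=O)N3CCCC3C2)cc1`: 80 nM

Compound 3, at 80 nM, has the lowest number of the three, so it is the strongest growth inhibitor measured so far. Its gaps to the other two compounds are beyond the scatter. The next compound, compound 4 `CSc1ccc(C2=C(c3ccc(Br)cc3)C(=O)N3CCCC3C2)cc1`, keeps the shared core but carries bromo in place of (oxiran-2-yl)methoxy on an aromatic carbon.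

Among the measured compounds shown here, no measured step covers this exact exchange. For the measured compounds named here, the nearest evidence is the one measured step, a 19-fold higher number from compound 1 to compound 2 (1.27 log units; beyond the scatter), which puts 3,4-difluorophenyl in place of 3-bromo-4-methoxyphenyl. It shows that changing the aryl group on this double-bonded ring carbon can shift the number widely. Neither compound 1, at 800 nM, nor compound 2, at 15000 nM, carries the (oxiran-2-yl)methoxy group, and both have higher numbers than compound 3. A large step towards a higher number in this assay is therefore expected, though three compounds make thin support. The expected step is a 19-fold higher number from compound 3 to compound 4 (1.27 log units; beyond the scatter). For compound 4 the estimated value is 1500 nM, with an expected range from 300 nM to 8000 nM.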

Compound 4, concentration for 50% growth inhibition: 7000 nM
Compound 4: the middle estimate sits 4.7-fold (0.67 log units) below what was measured; measured number inside the range.
By their numbers in this assay, from the lowest: compound 3; then compound 1; then compound 4; then compound 2.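

Among the compounds shown here, this exchange gives the first direct reading at this ring carbon: in this assay, putting bromo in place of (oxiran-2-yl)methoxy gives an 88-fold higher number from compound 3 to compound 4 (1.94 log units; beyond the scatter), so the low number of compound 3 does not survive once the (oxiran-2-yl)methoxy group is gone. Bromo alone does not make up for that loss, since changing the whole aryl group to 4-bromophenyl gives only a 2.1-fold lower number from compound 2 to compound 4 (0.33 log units; beyond the scatter), while the other comparison gives an 8.8-fold higher number from compound 1 to compound 4 (0.94 log units; beyond the scatter), leaving the 3-bromo-4-methoxyphenyl compound with the lower number of that pair. Nothing available here explains why the compound with the (oxiran-2-yl)methoxy group stands so far from the others.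

Only compound 3 carries this group, so the compounds shown cannot separate the three-membered ring from the ether link that holds it, and a plain methoxy or an open 2,3-dihydroxypropoxy chain on the same carbon would help to tell those two apart. From the compounds shown here alone, it also remains open whether other groups on this carbon, such as an amine or a carboxylic acid, could come close to compound 3 in this assay.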